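The source may report more compounds than this note shows. Statements on the series, on what has been measured and on what is new or still open speak of the compounds shown alone.

Compound 1 `Nc1nc(Cl)c2ncn(Cc3ccccc3CCl)c2n1`: 87100 nM
Compound 2 `ClCc1ccccc1Cn1cnc2nc(Cl)nc(Cl)c21`: > 100000 nM

Among the measured compounds shown here, in a functional assay on MCF7 cells (Homo sapiens) for cytotoxicity, read by sulforhodamine B assay, with a stated time of 48 h (on this read-out lower numbers stand for higher toxicity in this test and higher numbers for lower toxicity in this test), compound 1 gives 87100 nM, the only number among the two values shown. Compound 2 gives no number in this assay but only a limit, > 100000 nM, so that the set rests on the limit of > 100000 nM in this assay, at which 1 of the 2 values shown sits, for one of its entries. For the measured compounds named here, with only a number and a limit on hand, no step between measured compounds can be drawn.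

Compound 3 `ClCc1ccccc1Cn1cnc2c(Cl)ncnc21` follows from compound 1 by a single change: hydrogen in place of amino on an aromatic carbon. Going by the values given here, no measured pair covers this change, so the size of the step in this assay is open; the author expects a modest rise in the number, at the edge of the usual scatter rather than far beyond it, given that compound 2 in this assay sits at a limit, > 100000 nM.

Compound 3 is therefore estimated at 150000 nM, between 50000 nM and 400000 nM, which would mean a step of a 1.7-fold higher number from compound 1 to compound 3 (0.24 log units; within the scatter).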

Compound 3, concentration lethal to 50% of the cells: > 100000 nM
Compound 3 ended at the assay's limit; the forecaster's own chance of this, stated with the estimate: 60%; the middle value does not contradict the limit.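

Among the compounds shown here, at this aromatic carbon between two ring nitrogen atoms, the amino group is the only thing separating compound 1 from compound 3, and its replacement by hydrogen gives an at least 1.1-fold higher number from compound 1 to compound 3 (0.05 log units; that floor lies within the scatter) in this assay. Compound 3 reads > 100000 nM, which is a limit of the assay and not a number, so the change is shown only as a floor that does not go beyond the scatter. The limit now also shapes what the set can show about this position: the limit of > 100000 nM in this assay, at which 2 of the 3 values shown sit.

From the compounds shown here alone, the true size of the step remains open, as does how far compound 3 lies past its limit. Also open, going by these compounds, is whether a methylamino group, a hydroxyl group or a methoxy group at this carbon would give a number in this assay.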